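Pyridin-4-yl in place of bromo: compound 2 to compound 4

The compounds below may be only part of what the source reports. "The series", "measured", "known", "first", "only" and "open" are said of these compounds alone.

Of the compounds shown here, three have been read in an ADME assay on J774.A1 cells (Mus musculus) for cytotoxicity, read by MTT assay, with a stated time of 72 h; a higher number here means that more compound is tolerated, a lower number that less compound is tolerated. Compound 1 `CCC1(c2ccccc2OC)CC(S(=O)(=O)c2ccc(F)cc2)=C(c2ccc(/C(N)=N\O)cc2)O1` gives 9880 nM. Compound 2 `CC1(c2ccc(Br)cc2)CC(S(=O)(=O)c2ccc(F)cc2)=C(c2ccc(/C(N)=N\O)cc2)O1` gives 10500 nM. Compound 3 `CC1(Cc2ccccc2)CC(S(=O)(=O)c2cccc(C(F)(F)F)c2)=C(c2ccc(/C(N)=N\O)cc2)O1` gives 14500 nM. Compound 2 stands second highest of the three numbers; compound 1 is nearest and compound 3 furthest, and both gaps lie within the scatter, so the three measured compounds read as a single level of tolerated concentration rather than as an order.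

Compound 4 `CC1(c2ccc(-c3ccncc3)cc2)CC(S(=O)(=O)c2ccc(F)cc2)=C(c2ccc(/C(N)=N\O)cc2)O1` has not yet been measured. It differs from compound 2 by pyridin-4-yl in place of bromo on an aromatic carbon. Among the measured compounds shown here, no pair of measured compounds differs in only one place, so no measured step speaks to this position; the measured compounds differ at several places at once and still sit together in this assay. With the three numbers so close and nothing pulling in a direction, the step from compound 2 to compound 4 is expected to be small, most likely none beyond the scatter, and the estimated step of a 1.3-fold lower number from compound 2 to compound 4 (0.12 log units; within the scatter) carries only a slight lean to a lower number. Compound 4 is therefore expected to give about 8000 nM in this assay, with a range from 3000 nM to 20000 nM.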

Compound 4, half-maximal cytotoxic concentration: 6750 nM
Compound 4: the middle estimate sits 1.2-fold (0.07 log units) above what was measured; measured number inside the range.
By their numbers in this assay, from the lowest: compounds 4, 1, 2 and 3 (each within the scatter of the next, the first and the last beyond it).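

In this assay, among the compounds shown here, the series now has its first step at a single place, a 1.6-fold lower number from compound 2 to compound 4 (0.19 log units; within the scatter), so one position can be read on its own for the first time. On this aromatic carbon, para to a large group, bromo, a single heavy atom with no ring, gives way to pyridin-4-yl, with six heavy atoms, a six-membered aromatic ring and one hydrogen-bond acceptor, and the step stays within the scatter despite that added size. No measurement on these compounds accounts for the size of the step.

On these data alone, whether the position accepts other kinds of group remains open: an amine such as dimethylamino, a carboxylic acid or a longer alkyl chain on the same carbon would test this, and phenyl or pyridin-3-yl would show whether the placing of the ring nitrogen matters at all. For the compounds shown here, the places at which compound 1 and compound 3 depart from compound 2 have no single-place steps of their own, so those steps cannot be read.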